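The source may hold more compounds than are shown below. What is called first, only, known or untested is meant among the compounds shown, and "the series" means these compounds.

The series shares the core of compound 1 `COc1cc(-c2nnc(SCC(=O)c3ccc(Cl)cc3)n2N)cc(OC)c1OC`. In a functional assay on PC-3 cells (Homo sapiens) for antiproliferative activity, read by MTT assay, with a stated time of 48 h (a higher number here means a weaker inhibitor, a lower number a stronger inhibitor), compound 1 gives > 100000 nM, which is a limit of the assay rather than a number. Compound 2 `COc1cc(-c2nnc(SCC(=O)c3ccc(F)c(F)c3)n2N)cc(OC)c1OC` carries a 3,4-difluorophenyl in place of the 4-chlorophenyl on the carbonyl carbon. In this assay compound 2 gives > 100000 nM, again a limit of the assay and not a number. The step that the two limits leave unreadable from compound 1 to compound 2 therefore cannot be read. Both values sit at the limit of > 100000 nM in this assay, at which 2 of the 2 values shown sit. Compound 2 thus stands at the limit, with no number beneath it to rank.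

Compound 3 `COc1cc(-c2nnc(SCC(=O)Nc3ccccc3)n2N)cc(OC)c1OC` follows: anilino in place of 3,4-difluorophenyl on a carbonyl carbon. Among the measured compounds shown here, only one measured step touches this position, a step that the two limits leave unreadable from compound 1 to compound 2, and its size is not readable. For the measured compounds named here, no measured compound shows a step out of the limit, so for compound 3 no step beyond the scatter is expected in this assay in either direction. The expected step is a number no higher from compound 2 to compound 3 (the limit leaves the size open). Compound 3 is estimated to give 100000 nM, with a range from 30000 nM to 300000 nM, and the assay is expected most likely to report only a limit once more.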

Compound 3, half-maximal inhibitory concentration: 37900 nM
The estimate for compound 3 lay 2.6-fold (0.42 log units) above the measured number, and the stated range covers the measured number.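

In this assay, anilino in place of 3,4-difluorophenyl on a carbonyl carbon gives an at least 2.6-fold lower number from compound 2 to compound 3 (0.42 log units; beyond the scatter), and anilino in place of 4-chlorophenyl at the same place gives an at least 2.6-fold lower number from compound 1 to compound 3 (0.42 log units; beyond the scatter); this position can therefore bring the read-out off the limit, which the exchange between the two halogenated phenyl groups did not show. Compound 3 keeps a six-membered aromatic ring of carbon only, so the exchange that produced a number adds the anilino nitrogen with its hydrogen-bond donor and removes the halogens from the ring. The size of both steps stays open on one side, since the values of compound 1 and compound 2 are limits of the assay and not numbers: the limit of > 100000 nM in this assay, at which 2 of the 3 values shown sit.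

The compounds shown do not separate the contribution of the anilino nitrogen from that of the halogen-free ring, a question that a chloroanilino or a methylated anilino nitrogen would bear on. As far as these compounds go, how far the position tolerates a longer chain between carbonyl and ring, as in benzylamino, also stays open.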